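The source may hold more compounds than are shown below. What is called first, only, known or untested is meant among the compounds shown, and "the series" means these compounds.

For the measured compounds named here, compound 3 `CCCCn1cnc(CN2CCN(c3cccc4[nH]c(-c5ccc(C(C)(C)C)cc5)nc34)CC2)c1C` stands second highest of the three numbers so far obtained in an assay on isolated protein for displacement of a labelled ligand from Gonadotropin-releasing hormone receptor (Rattus norvegicus); on this read-out lower numbers stand for stronger inhibition and higher numbers for weaker inhibition: in this assay compound 3 gives 49 nM. Its nearest neighbour is compound 1 `Cc1nc(CN2CCN(c3cccc4[nH]c(-c5ccc(C(C)(C)C)cc5)nc34)CC2)c[nH]1`, which in this assay gives 28 nM; the step of a 1.8-fold higher number from compound 1 to compound 3 (0.24 log units; within the scatter) is within the scatter. The furthest is compound 2 `CCc1nc(C)c(CN2CCN(c3cccc4[nH]c(-c5ccc(C(C)(C)C)cc5)nc34)CC2)o1`, which in this assay gives 320 nM; the step of a 6.5-fold lower number from compound 2 to compound 3 (0.81 log units; beyond the scatter) lies beyond the scatter, as does an 11-fold higher number from compound 1 to compound 2 (1.06 log units; beyond the scatter).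

Compound 4 `CCc1nc(CN2CCN(c3cccc4[nH]c(-c5ccc(C(C)(C)C)cc5)nc34)CC2)cn1C` differs from compound 3 in one place: 2-ethyl-1-methyl-1H-imidazol-4-yl in place of 1-butyl-5-methyl-1H-imidazol-4-yl on a saturated chain carbon bound to an amine nitrogen in a ring. Both groups are imidazol-4-yl rings set on a saturated chain carbon bound to an amine nitrogen in a ring; only the alkyl groups on that ring are rearranged and shortened. The step that bears most directly on this is a 1.8-fold higher number from compound 1 to compound 3 (0.24 log units; within the scatter), in which the alkyl pattern on an imidazol-4-yl ring was changed without leaving the scatter. The steps of an 11-fold higher number from compound 1 to compound 2 (1.06 log units; beyond the scatter) and a 6.5-fold lower number from compound 2 to compound 3 (0.81 log units; beyond the scatter) were large, but each involved exchanging the imidazolyl ring for an oxazolyl ring, which compound 4 does not do. One therefore expects no step beyond the scatter in this assay, the estimated step being a 1.2-fold lower number from compound 3 to compound 4 (0.09 log units; within the scatter). For compound 4 the estimate in this assay is 40 nM, with a range from 15 nM to 120 nM.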

Compound 4, half-maximal inhibitory concentration: 78 nM
Estimate against measurement, compound 4: 2.0-fold (0.29 log units) below, and the stated range covers the measured number.
By their numbers in this assay, from the lowest: compounds 1, 3 and 4 (each within the scatter of the next, the first and the last beyond it); then compound 2.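

In this assay, for the compounds shown here, moving from the 1-butyl-5-methyl-1H-imidazol-4-yl group to the 2-ethyl-1-methyl-1H-imidazol-4-yl group changes the group's alkyl pattern and size without leaving the scatter (a 1.6-fold higher number from compound 3 to compound 4 (0.20 log units; within the scatter)), yet the same group set against the one in compound 1 gives the first step beyond the scatter between two imidazol-4-yl groups (a 2.8-fold higher number from compound 1 to compound 4 (0.44 log units; beyond the scatter)), where compound 3 had stayed within it. Exchanging the 2-ethyl-4-methyl-1,3-oxazol-5-yl group for this imidazolyl group also lowers the number (a 4.1-fold lower number from compound 2 to compound 4 (0.61 log units; beyond the scatter)), so compound 2 now stands beyond the scatter from all three imidazolyl compounds, and the alkyl pattern on the imidazol-4-yl ring is seen to have a modest effect of its own in this series. Nothing measured here accounts for the size of any of these steps.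

The compounds shown leave open which alkyl group accounts for the gap from compound 1 to compound 4, since that change alters more than one place on the ring at once. They also leave open how a pyridine ring, or an imidazol-4-yl ring carrying an amine or a carboxylic acid on a longer chain, would read in this assay.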